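Aryl urea swap on a shared cyclohexyl ether core

A few compounds are considered here, and "the series" means these few. Any claim that something is new, unique, unknown or untested is made for them only; others in the source may bear on it.

Compound 1 `O=C(Nc1ccccc1F)N[C@H]1CC[C@H](Oc2ccc(F)cc2)CC1` carries the only numeric result in the set: in a functional assay on CRL2813 cells (Homo sapiens) for cytotoxicity, read by sulforhodamine B assay, with a stated time of 5 days (on this read-out lower numbers stand for stronger inhibition and higher numbers for weaker inhibition), compound 1 gives 17500 nM. Compound 2 `O=C(Nc1cccc(C(F)(F)F)c1)N[C@H]1CC[C@H](O)CC1` is reported in this assay only as > 20000 nM, a limit of the assay and not a number. Both results therefore sit at or near (the limit of > 20000 nM in this assay, at which 1 of the 2 values shown sits), so compound 1 stands as weakly active.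

Compound 3 `COc1cccc(NC(=O)N[C@H]2CC[C@H](Oc3ccc(F)cc3)CC2)c1` differs from compound 1 by 3-methoxyphenyl in place of 2-fluorophenyl on an amide-type nitrogen. Among the compounds with values here, no measured pair isolates this change, so the step of a 1.2-fold lower number from compound 1 to compound 3 (0.07 log units; within the scatter) is expected to be small, with no clear direction beyond the usual scatter. Compound 3 is expected to give 15000 nM in this assay, in the range 6000 nM to 40000 nM.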

Compound 3, half-maximal inhibitory concentration: 14000 nM
Compound 3: middle estimate off by 1.1-fold (0.03 log units), on the high side; low and high end bracket the measured number.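

Within the data shown here, this is the first readable step at this position: in this assay, 3-methoxyphenyl in place of 2-fluorophenyl on an amide-type nitrogen gives a 1.3-fold lower number from compound 1 to compound 3 (0.10 log units; within the scatter). The exchange of these two aryl groups therefore leaves the number within the scatter, even with a hydrogen-bond acceptor entering. Both numbers remain in the weak range, close to the limit of the read-out: the limit of > 20000 nM in this assay, at which 1 of the 3 values shown sits.

Still open, as far as these compounds go, is whether any group at this nitrogen can move the number beyond the scatter. A phenyl ring bearing a carboxylic acid or an amine would test this.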